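The source may report more compounds than this note shows. Statements on the series, on what has been measured and on what is new or still open speak of the compounds shown alone.

Measured so far in a functional assay on MCF7 cells (Homo sapiens) for antiproliferative activity; a higher number here means a weaker inhibitor, a lower number a stronger inhibitor:
compound 1 `CC(C)=CCc1cc(C(=O)Nc2cc3ccc(OCCCN4CCCC4)c(C)c3oc2=O)ccc1O` gives 990 nM;
compound 2 `CCN(CC)CCCOc1ccc2cc(NC(=O)c3ccc(O)c(CC=C(C)C)c3)c(=O)oc2c1C` gives 6390 nM;
compound 3 `CC(C)=CCc1cc(C(=O)Nc2cc3ccc(OCCCNCC(=O)O)c(C)c3oc2=O)ccc1O` gives 18100 nM.

Compound 1 has the lowest number of the three; its nearest neighbour is compound 2 (a 6.5-fold higher number from compound 1 to compound 2 (0.81 log units; beyond the scatter)), and the step to compound 3 is larger (an 18-fold higher number from compound 1 to compound 3 (1.26 log units; beyond the scatter)). Between the two variants, a 2.8-fold higher number from compound 2 to compound 3 (0.45 log units; beyond the scatter). Both replacements of pyrrolidin-1-yl so far have given higher numbers.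

Compound 4 `CC(C)=CCc1cc(C(=O)Nc2cc3ccc(OCCCNc4ccccc4)c(C)c3oc2=O)ccc1O` differs from compound 1 in the same place: anilino in place of pyrrolidin-1-yl on a saturated chain carbon, three bonds along the chain from an oxygen on an aromatic ring. The two measured steps from compound 1 both bear on this, one modest and one large, and both point the same way. Compound 4 is therefore expected to give a higher number than compound 1 in this assay, with the step estimated around the size of the two already seen rather than within the scatter, roughly a 7.1-fold higher number from compound 1 to compound 4 (0.85 log units; beyond the scatter). The estimate for compound 4 in this assay is 7000 nM, expected to lie between 2000 nM and 25000 nM.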

Compound 4, half-maximal inhibitory concentration: > 50000 nM
Compound 4 ended at the assay's limit (the forecaster's own chance of this, stated with the estimate: 5%); middle value at least 7.1-fold (0.85 log units) from the limit.
By their numbers in this assay, from the lowest: compound 1; then compound 2; then compound 3. At a limit, above all of these: compound 4.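

In this assay compound 4 gives > 50000 nM, which is a limit of the assay and not a number. Anilino on this saturated chain carbon therefore goes further than either earlier replacement of pyrrolidin-1-yl, with an at least 50-fold higher number from compound 1 to compound 4 (1.70 log units; beyond the scatter), and the 3-anilinopropyl compound also falls behind both other variants, with an at least 7.8-fold higher number from compound 2 to compound 4 (0.89 log units; beyond the scatter) and an at least 2.7-fold higher number from compound 3 to compound 4 (0.44 log units; beyond the scatter). All three replacements of pyrrolidin-1-yl shown give higher numbers, and the range at this position now runs from measurable values to the limit of the assay.

From the compounds shown here alone, how far compound 4 lies past the limit stays open, so the steps to it give only a minimum size. Also open, going by these compounds, is whether piperidine, morpholine or benzylamino on the same propyl chain, or pyrrolidin-1-yl on a shorter ethyl chain, would match or improve on compound 1.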